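Tosylation of the phenol on two different cores

A few compounds are considered here, and "the series" means these few. Any claim that something is new, unique, unknown or untested is made for them only; others in the source may bear on it.

Compound 1 `C=C1C(=O)[C@]23C[C@@]1(O)CC[C@H]2c1ccc(O)c(C)c1[C@@H]3Cn1cc(-c2ccc(C)cc2)nn1` gives 1260 nM in a functional assay on A549 cells (Homo sapiens) for cytotoxicity, read by MTT assay, with a stated time of 4 days; on this read-out lower numbers stand for stronger inhibition and higher numbers for weaker inhibition. Compound 2 `C=C1C(=O)[C@]23C[C@@]1(O)CC[C@H]2c1ccc(OS(=O)(=O)c2ccc(C)cc2)c(C)c1[C@@H]3Cn1cc(-c2ccc(C)cc2)nn1` gives 1830 nM in this assay. The change between them is (4-methylphenyl)sulfonyl in place of hydrogen on an oxygen on an aromatic ring, and the step of a 1.5-fold higher number from compound 1 to compound 2 (0.16 log units; within the scatter) is small. Compound 3 `Cc1ccc(-c2cn(C[C@H]3c4c(ccc(O)c4C)[C@@H]4CC[C@@]5(C)C[C@]43CC5=O)nn2)cc1` rests on another core; how the two cores differ is not broken down here. In this assay compound 3 reaches only > 20000 nM, which is a limit of the assay and not a number (the limit of > 20000 nM in this assay, at which 1 of the 3 values shown sits). Compound 4 `Cc1ccc(-c2cn(C[C@H]3c4c(ccc(OS(=O)(=O)c5ccc(C)cc5)c4C)[C@@H]4CC[C@@]5(C)C[C@]43CC5=O)nn2)cc1` is not yet measured; it carries (4-methylphenyl)sulfonyl in place of hydrogen on an oxygen on an aromatic ring, the same change as compound 2, at a place described in the same words. The step from compound 3 to compound 4 is expected to be a step that the limit leaves unreadable from compound 3 to compound 4, resting on the small step of a 1.5-fold higher number from compound 1 to compound 2 (0.16 log units; within the scatter) seen on the other core. Compound 3 sits at the limit > 20000 nM. Compound 4 is therefore expected at about 30000 nM, within a range from 12000 nM to 80000 nM, and most likely to be reported again only as a limit.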

Compound 4, half-maximal inhibitory concentration: > 20000 nM
Compound 4 ended at the assay's limit (the forecaster's own chance of this, stated with the estimate: 85%); the middle value lies beyond the limit too.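

In this assay compound 4 gives > 20000 nM, a limit and not a number, so no step from compound 3 can be read: the limit of > 20000 nM in this assay, at which 2 of the 4 values shown sit.

Left open is what (4-methylphenyl)sulfonyl in place of hydrogen does on the core of compound 3.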